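The source may hold more compounds than are shown below. What is called first, only, known or untested is meant among the compounds shown, and "the series" means these compounds.

Of the compounds shown here, three sharing one core have been measured in a functional assay on brain (Rattus norvegicus, strain Wistar) for inhibition; on this read-out higher numbers stand for weaker inhibition and lower numbers for stronger inhibition. Compound 1 `CCCCc1ccc(-c2c(C)[nH]c(=O)n2C)cc1` gives 10700 nM. Compound 2 `CCCc1ccc(-c2c(C)[nH]c(=O)n2C)cc1` gives 21500 nM. Compound 3 `CCCCCCCOc1ccc(-c2c(C)[nH]c(=O)n2C)cc1` gives 5700 nM. Compound 1 differs from compound 2 by methyl in place of hydrogen on a saturated chain carbon, three bonds along the chain from an aromatic carbon, and this change gave a 2.0-fold lower number from compound 2 to compound 1 (0.30 log units; within the scatter). The difference between the core of compound 2 and that of compound 3 is not broken down here. Compound 4 `CCCCCCCCOc1ccc(-c2c(C)[nH]c(=O)n2C)cc1` has not yet been measured; it differs from compound 3 by methyl in place of hydrogen on a saturated chain carbon, seven bonds along the chain from an oxygen on an aromatic ring. Among the compounds with values here, that is the same kind of change as the one from compound 2 to compound 1, though at another place: seven bonds along the chain from an oxygen on an aromatic ring rather than three bonds along the chain from an aromatic carbon. A step of a 1.5-fold lower number from compound 3 to compound 4 (0.18 log units; within the scatter) in this assay is expected, resting on what compound 1 showed because a 2.0-fold lower number from compound 2 to compound 1 (0.30 log units; within the scatter). Compound 4 is therefore estimated at 3800 nM, expected between 1500 nM and 9000 nM.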

Compound 4, half-maximal inhibitory concentration: 4000 nM
For compound 4 the middle estimate is 1.1-fold (0.02 log units) below the measured one; measured number inside the range.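

Adding a methyl in place of hydrogen on a saturated chain carbon, seven bonds along the chain from an oxygen on an aromatic ring, gave a 1.4-fold lower number from compound 3 to compound 4 (0.15 log units; within the scatter) in this assay. The change thus read alike on the two cores, with no difference that can be told apart: the same change on two cores in this assay, a 2.0-fold lower number (0.30 log units; within the scatter) from compound 2 to compound 1 and a 1.4-fold lower number (0.15 log units; within the scatter) from compound 3 to compound 4, 1.4-fold (0.15 log units) apart, within the scatter of two such steps
This does not show that the methyl has a real effect on either core, as each step alone lies within the scatter, and two pairs set no rule for other cores in the series.

The compounds shown leave open how a chain longer than that of compound 4 would read in this assay. They also leave open what an amine or a carboxylic acid in place of the chain would give.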